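Moving a pyrazole attachment point in a microsomal stability series

This account rests on a few compounds, and the source may have more. Where it says the series, first, only, none or still open, it means among the compounds named here.

Measured so far:
Compound 1 `CC(C)(C)C(=O)N1N=CCC1c1cocn1` — in an ADME assay on microsomes (Homo sapiens) for metabolic stability (on this read-out higher numbers stand for a longer-lived compound and lower numbers for a shorter-lived compound), compound 1 gives > 1.5 h, which is a limit of the assay.
Compound 2 `O=C(c1cn[nH]c1)N1CCC(C(=O)N2N=CCC2c2ccccc2)CC1` — in this assay compound 2 gives > 2.75 h, which is also a limit.

Both numbers shown are limits rather than measured values, as the limit of > 1.5 h in this assay, at which 1 of the 2 values shown sits, and the limit of > 2.75 h in this assay, at which 1 of the 2 values shown sits, make plain, so compound 2 stands at the upper edge of what this assay reports and cannot be ranked against compound 1 on these numbers.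

Compound 3 `O=C(c1cc[nH]n1)N1CCC(C(=O)N2N=CCC2c2ccccc2)CC1` has not yet been measured. It differs from compound 2 in one place: 1H-pyrazol-3-yl in place of 1H-pyrazol-4-yl on a carbonyl carbon. Since no step between measured compounds is shown here, there is nothing to tie this change to a change in half-life. The expectation is therefore a step of no size beyond the scatter, a number no higher from compound 2 to compound 3 (the limit leaves the size open). Compound 3 is estimated to give 2.75 h, with a range from 1.4 h to 5.5 h, and most likely again only a limit.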

Compound 3, half-life: > 2.75 h
Compound 3 was reported as a limit; the forecaster's own chance of this, stated with the estimate: 70%; the middle value lies on the limit itself.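

In this assay compound 2 and compound 3 both stand at the same limit, so no step can be read between them: the limit of > 2.75 h in this assay, at which 2 of the 3 values shown sit. The compounds shown leave open how long either compound truly lasts, and whether 1H-pyrazol-3-yl in place of 1H-pyrazol-4-yl changes half-life at all.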